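Moving two chlorines on the phenyl ring of compound 3

A few compounds are considered here, and "the series" means these few. Any claim that something is new, unique, unknown or untested is made for them only; others in the source may bear on it.

Compound 3 `O=C(/C=C/c1ccccc1Oc1ncnc2ccc(Cl)cc12)/C=C/c1cccc(Cl)c1Cl` gives 73.8% in a functional assay on PC-3 cells (Homo sapiens) for inhibition, read by MTT assay, with a stated time of 72 h, tested at 10 uM (a higher number here means more inhibition of growth at the concentration tested, a lower number less inhibition of growth), and stands highest of the three measured compounds. Compound 1 `O=C(/C=C/c1ccc(Cl)c([N+](=O)[O-])c1)/C=C/c1ccccc1Oc1ncnc2ccc(Cl)cc12` gives 62.5%, and compound 2 `O=C(/C=C/c1ccc(Cl)c(Cl)c1)/C=C/c1ccccc1Oc1ncnc2ccc(Cl)cc12` gives 42.2%. The change to compound 4 `O=C(/C=C/c1ccccc1Oc1ncnc2ccc(Cl)cc12)/C=C/c1c(Cl)cccc1Cl` is 2,6-dichlorophenyl in place of 2,3-dichlorophenyl on a double-bonded chain carbon bound to a double-bonded chain carbon. Going by the values given here, no measured step rearranges the chlorines in just this way, but the step of a number 31.6 percentage points higher from compound 2 to compound 3 (beyond the scatter) shows that the arrangement of two chlorines on this ring can shift this assay strongly, while a number 11.3 percentage points higher from compound 1 to compound 3 (beyond the scatter) was modest. Compound 4 is therefore expected to lose some inhibition, with a number 13.8 percentage points lower from compound 3 to compound 4 (beyond the scatter) as the anticipated step, though the direction is uncertain. Compound 4 is estimated at 60%, within a range of 35% to 85%.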

Compound 4, percent growth inhibition at one concentration: 70.1%
Estimate against measurement, compound 4: 10.1 percentage points below; the measured number falls inside the stated range.
By their numbers in this assay, from the lowest: compound 2; then compounds 1, 4 and 3 (each within the scatter of the next, the first and the last beyond it).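

In this assay, moving the chlorines from 2,3-dichlorophenyl to 2,6-dichlorophenyl leaves the reading essentially in place (a number 3.7 percentage points lower from compound 3 to compound 4 (within the scatter)), so the two arrangements cannot be told apart here. Compound 2 with its 3,4-dichlorophenyl stays the outlier (a number 27.9 percentage points higher from compound 2 to compound 4 (beyond the scatter)), whereas the 4-chloro-3-nitrophenyl group offers no separation (a number 7.6 percentage points higher from compound 1 to compound 4 (within the scatter)). Nothing available explains why these arrangements differ or agree. Still open, from the compounds shown here alone, is how this ring would read carrying a single chlorine, a methoxy group or an amine, and whether an unsubstituted phenyl would hold the reading.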